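A few compounds are considered here, and "the series" means these few. Any claim that something is new, unique, unknown or untested is made for them only; others in the source may bear on it.

Measured compounds:
compound 1, `COc1ccccc1NC(=O)N1CCC(c2nc(-c3ccc4ccccc4n3)no2)CC1` — 410 nM
compound 2, `Cn1c(-c2noc(C3CCN(C(=O)NC4CCS(=O)(=O)CC4)CC3)n2)nc2ccccc21` — 350 nM

Two compounds share the core and carry a measurement in a functional assay on Shh Light II cells (Mus musculus) for inhibition, read by a luciferase reporter; a higher number here means a weaker inhibitor, a lower number a stronger inhibitor. Compound 1 gives 410 nM and compound 2 gives 350 nM. Compound 1 has the higher of the two numbers, but the gap to compound 2 lies within the scatter of this assay, so the two stand together rather than in order.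

Compound 3, `O=C(OC1CCCCC1)N1CCC(c2nc(-c3ccc4ccccc4n3)no2)CC1`, has not yet been tested in this assay. It differs from compound 1 in one place: cyclohexyloxy in place of (2-methoxyphenyl)amino on a carbonyl carbon. The (2-methoxyphenyl)amino leaves and the cyclohexyloxy enters on the carbonyl carbon. Among the compounds with values here, no step between measured compounds covers a change of this kind, so the measured pair gives no direct guide.

The step is expected to be small, with a slight drift toward a weaker inhibitor, at most near the edge of the scatter. Compound 3 is estimated to give 700 nM in this assay, in a range of 250 nM to 2500 nM, an expected change of a 1.7-fold higher number from compound 1 to compound 3 (0.23 log units; within the scatter).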

Compound 3, half-maximal inhibitory concentration: 580 nM
Beside the measured number, compound 3's estimate is 1.2-fold (0.08 log units) above it; measured number inside the range.
By their numbers in this assay, from the lowest: compounds 2, 1 and 3 (each within the scatter of the next).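

On a carbonyl carbon whose other neighbour is an amide-type nitrogen in a ring, cyclohexyloxy in place of (2-methoxyphenyl)amino gives a 1.4-fold higher number from compound 1 to compound 3 (0.15 log units; within the scatter) in this assay and so leaves the two compounds together. The aromatic ring and the hydrogen-bond donor of the (2-methoxyphenyl)amino group can therefore both be lost at this position without a change that stands clear of the scatter, at least when a non-aromatic ring of carbon only takes their place. No supporting evidence bears on this result.

As far as these compounds go, whether this position would accept a much smaller group, such as methoxy, or a longer chain, such as hexyloxy, remains open. Also open, from the compounds shown here alone, is whether a carboxylic acid or an amine carried on the cyclohexyl ring would keep the number in the same range.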